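Swapping the aryl group on the dienone core: compound 4

The compounds below may be only part of what the source reports. "The series", "measured", "known", "first", "only" and "open" are said of these compounds alone.

Measured in a functional assay on MCF7 cells (Homo sapiens) for cytotoxicity, read by MTT assay, with a stated time of 72 h; on this read-out higher numbers stand for weaker inhibition and lower numbers for stronger inhibition:
compound 1, `COc1cccc(/C=C2\CCC/C(=C\c3ccccc3Cl)C2=O)c1OC`, gives 11300 nM
compound 2, `COc1cccc(/C=C2\CCC/C(=C\c3cccc(OC)c3OC)C2=O)c1`, gives 5900 nM
compound 3, `COc1ccc(/C=C2\CCC/C(=C\c3cccc(Br)c3)C2=O)cc1OC`, gives 5300 nM

Compound 3 has the lowest number of the three, but its gap to compound 2 is within the scatter; only compound 1 lies beyond it. Compound 4, `COc1ccc(/C=C2\CCC/C(=C\c3ccc(O)c(Cl)c3)C2=O)cc1OC`, is not yet measured. It differs from compound 3 in one place: 3-chloro-4-hydroxyphenyl in place of 3-bromophenyl on a double-bonded chain carbon bound to a double-bonded ring carbon. For the measured compounds named here, the only measured step at this place is a 1.9-fold lower number from compound 1 to compound 2 (0.28 log units; within the scatter), where one aryl group replaced another with no change beyond the scatter. On that basis, compound 4 is expected to stay close to compound 3, with a step of about a 1.1-fold lower number from compound 3 to compound 4 (0.03 log units; within the scatter). The estimate for compound 4 is 5000 nM, within 2000 nM to 12000 nM.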

Compound 4, half-maximal inhibitory concentration: 12300 nM
Compound 4: middle estimate off by 2.5-fold (0.39 log units), on the low side; the measured number lies above the stated range.
By their numbers in this assay, from the lowest: compounds 3, 2, 1 and 4 (each within the scatter of the next, the first and the last beyond it).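

In this assay, for the compounds shown here, 3-chloro-4-hydroxyphenyl in place of 3-bromophenyl gives a 2.3-fold higher number from compound 3 to compound 4 (0.37 log units; beyond the scatter), the only step at this place that lies beyond the scatter, so this position does not tolerate every aryl exchange equally. The entering group carries a hydrogen-bond donor and acceptor that the leaving group lacks, and chlorine instead of bromine, and this single step cannot separate those changes. Nothing available explains the higher number.

On these data alone, it remains open whether the hydroxyl or the chlorine accounts for the step, and how an aminophenyl or carboxyphenyl group would behave at this place.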